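This account rests on a few compounds, and the source may have more. Where it says the series, first, only, none or still open, it means among the compounds named here.

Measured compounds in a functional assay on SH-SY5Y cells (Homo sapiens) for cytotoxicity, read by MTT assay, with a stated time of 48 h; a higher number here means a weaker inhibitor, a lower number a stronger inhibitor:
compound 1 `COc1ccc(-c2cscc2-c2cc(OC)c(OC)c(OC)c2)cc1`: 480 nM
compound 2 `COc1ccc(-c2cscc2-c2cc(OC)c(OC)c(OC)c2)cc1O`: 79 nM
compound 3 `COc1ccc(-c2ccoc2-c2cc(OC)c(OC)c(OC)c2)cc1O`: 2.4 nM

Compound 2 to compound 1 is hydrogen in place of hydroxy on an aromatic carbon and gives a 6.1-fold higher number from compound 2 to compound 1 (0.78 log units; beyond the scatter). Compound 3 carries a different core from compound 2; the difference between the two cores is not broken down here. Compound 3 has the lowest number of the three, with compound 2 nearest and compound 1 furthest.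

Compound 4 `COc1ccc(-c2ccoc2-c2cc(OC)c(OC)c(OC)c2)cc1` is not yet measured. Compound 3 to compound 4 is hydrogen in place of hydroxy on an aromatic carbon, the same change as from compound 2 to compound 1, at the same place. Going by the values given here, for compound 4 the expected step is a 6.3-fold higher number from compound 3 to compound 4 (0.80 log units; beyond the scatter), set beside a 6.1-fold higher number from compound 2 to compound 1 (0.78 log units; beyond the scatter), because the one measured pair gave a 6.1-fold higher number from compound 2 to compound 1 (0.78 log units; beyond the scatter) and compound 3 starts from 2.4 nM. Compound 4 is estimated at 15 nM, with a range from 5 nM to 45 nM.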

Compound 4, half-maximal inhibitory concentration: 28 nM
For compound 4 the middle estimate is 1.9-fold (0.27 log units) below the measured one; measured number inside the range.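

In this assay, hydrogen in place of hydroxy on an aromatic carbon gives a 12-fold higher number from compound 3 to compound 4 (1.07 log units; beyond the scatter), the same direction as on the core of compound 1. The two steps cannot be told apart in size: the same change on two cores in this assay, a 6.1-fold higher number (0.78 log units; beyond the scatter) from compound 2 to compound 1 and a 12-fold higher number (1.07 log units; beyond the scatter) from compound 3 to compound 4, 1.9-fold (0.28 log units) apart, within the scatter of two such steps

The change therefore carries across these two cores in this assay, but two pairs do not show that it would hold on any further core or in any other assay, and they give no reason for the step.

Still open, on these data alone, is whether an amine or a fluorine on that aromatic carbon would behave more like hydroxy or more like hydrogen. The compounds shown also leave open whether a longer chain in place of the methoxy group at that ring would alter the step.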